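Iodo to methoxy on the shared core

A few compounds are considered here, and "the series" means these few. Any claim that something is new, unique, unknown or untested is made for them only; others in the source may bear on it.

In a functional assay on HCT-116 cells (Homo sapiens) for inhibition, read by MTT assay, with a stated time of 72 h (on this read-out higher numbers stand for weaker inhibition and lower numbers for stronger inhibition), compound 1 `COc1cc(/C=C/C(=O)c2ccc3ccccc3c2)cc(Br)c1OC` gives 11200 nM and compound 2 `COc1cc(/C=C/C(=O)c2ccc3ccccc3c2)cc(I)c1OC` gives 14400 nM. Compound 2 therefore stands level with compound 1 within the scatter, and these two values are the only reference points so far. Compound 3 `COc1cc(/C=C/C(=O)c2ccc3ccccc3c2)cc(OC)c1OC` differs from compound 2 as follows: methoxy in place of iodo on an aromatic carbon. This is methoxy in place of iodo on an aromatic carbon, ortho to a methoxy group. Among the compounds with values here, the one measured step that bears on it is a 1.3-fold higher number from compound 1 to compound 2 (0.11 log units; within the scatter), which swaps one halogen for another. Within the data shown here, no measured step removes the halogen, so this guide is loose. No step beyond the scatter is expected in this assay, though the range must stay wide. Compound 3 is estimated at 10000 nM, with an expected range of 3000 nM to 30000 nM. The expected change is a 1.4-fold lower number from compound 2 to compound 3 (0.16 log units; within the scatter).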

Compound 3, half-maximal inhibitory concentration: 13700 nM
The estimate for compound 3 lay 1.4-fold (0.14 log units) below the measured number; the range from low to high includes it.
By their numbers in this assay, from the lowest: compounds 1, 3 and 2 (each within the scatter of the next).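

In this assay, methoxy in place of iodo gives (a 1.1-fold lower number from compound 2 to compound 3 (0.02 log units; within the scatter)) and methoxy in place of bromo gives (a 1.2-fold higher number from compound 1 to compound 3 (0.09 log units; within the scatter)). The earlier pair compared only one halogen with another, whereas these steps show that, on this aromatic carbon ortho to a methoxy group, a methoxy group and either halogen cannot be told apart within the scatter, although methoxy brings more heavy atoms and a hydrogen-bond acceptor. No measured evidence accounts for this flat result.

Whether any group at this position can produce a step beyond the scatter remains open, since the compounds shown carry only bromo, iodo and methoxy there. An amine, a carboxylic acid or a longer chain on the same carbon would test that question on the shared core.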